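Swapping a benzyl for an ester-bearing chain

The source may hold more compounds than are shown below. What is called first, only, known or untested is meant among the compounds shown, and "the series" means these compounds.

Compound 1 `C#CCNC(=O)c1cn(CC(=O)OCc2ccccc2)nn1` gives > 100000 nM (a limit)
Compound 2 `C#CCNC(=O)c1cn(CCOC(C)=O)nn1` gives > 100000 nM (a limit)
Compound 3 `C#Cc1cccc(NC(=O)c2cn(Cc3ccccc3)nn2)c1` gives 14500 nM

Within the data shown here, in a functional assay on B16 cells (Mus musculus) for cytotoxicity, read by MTT assay, with a stated time of 48 h (on this read-out lower numbers stand for stronger inhibition and higher numbers for weaker inhibition), compound 3 gives 14500 nM and is the only compound with a true number so far. Compound 4 `C#Cc1cccc(NC(=O)c2cn(CC(=O)OCC)nn2)c1` keeps the amide end of compound 3 and changes the other end (ethoxycarbonyl in place of phenyl on a saturated chain carbon bound to an aromatic nitrogen): ethoxycarbonyl in place of phenyl on a saturated chain carbon bound to an aromatic nitrogen. Among the measured compounds shown here, no measured pair shows this change alone. Compound 1 also carries an ester at that end and reads > 100000 nM as a limit. Compound 2 carries an ester too and reads > 100000 nM as a limit. Both also differ from compound 3 at the amide end, so they are only a loose guide. A weakening is expected, with an estimated size (a 3.1-fold higher number from compound 3 to compound 4 (0.49 log units; beyond the scatter)). The estimate for compound 4 is 45000 nM (expected range 15000 nM to 100000 nM).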

Compound 4, half-maximal inhibitory concentration: 91000 nM
The estimate for compound 4 lay 2.0-fold (0.31 log units) below the measured number; the range from low to high includes it.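

With the amide end held fixed, replacing phenyl with ethoxycarbonyl at this position now has a measured size in this assay: a 6.3-fold higher number from compound 3 to compound 4 (0.80 log units; beyond the scatter). The ester-bearing compound 4 therefore reads weaker than its phenyl partner, yet it still gives a true number. Compounds 1 and 2 also carry esters at this end, but they differ at the amide end too and give no number here, only a limit: the limit of > 100000 nM in this assay, at which 2 of the 4 values shown sit.

The compounds shown leave open how an amine, a carboxylic acid or a longer chain would read in this place. They therefore cannot separate the effect of losing phenyl from that of adding the ester.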